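Cinnamide in place of dimethylphenyl: cytotoxicity expected unchanged

The source may report more compounds than this note shows. Statements on the series, on what has been measured and on what is new or still open speak of the compounds shown alone.

Three amides on a shared core have been measured in a functional assay on C8166 cells (Homo sapiens) for cytotoxicity, read by MTT assay; on this read-out higher numbers stand for lower toxicity in this test and lower numbers for higher toxicity in this test. Compound 1 `Cc1ccc(C(=O)Nc2cc(Cl)ccc2OCC(=O)Nc2ccc(S(N)(=O)=O)cc2C)cc1` gives 54200 nM in this assay. Compound 2 `Cc1cc(S(N)(=O)=O)ccc1NC(=O)COc1ccc(Cl)cc1NC(=O)c1cccc([N+](=O)[O-])c1` gives 58800 nM in this assay, and compound 3 `Cc1ccc(C(=O)Nc2cc(Cl)ccc2OCC(=O)Nc2ccc(S(N)(=O)=O)cc2C)c(C)c1` gives 47600 nM in this assay. The steps among them are small: a 1.1-fold higher number from compound 1 to compound 2 (0.04 log units; within the scatter), a 1.1-fold lower number from compound 1 to compound 3 (0.06 log units; within the scatter) and a 1.2-fold lower number from compound 2 to compound 3 (0.09 log units; within the scatter). Compound 3 stands at the low end of the three numbers, yet its nearest neighbour compound 1 and its furthest neighbour compound 2 both lie within the scatter of it, so no order can be read.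

Compound 4 `Cc1cc(S(N)(=O)=O)ccc1NC(=O)COc1ccc(Cl)cc1NC(=O)/C=C/c1ccccc1` has not yet been measured in this assay. It differs from compound 3 in one place: 2-phenylethenyl in place of 2,4-dimethylphenyl on a carbonyl carbon. Two measured steps alter the same carbonyl carbon, a 1.1-fold higher number from compound 1 to compound 2 (0.04 log units; within the scatter) and a 1.2-fold lower number from compound 2 to compound 3 (0.09 log units; within the scatter), and both stayed within the scatter, even where 3-nitrophenyl replaced 4-methylphenyl. Among the measured compounds shown here, the 2-phenylethenyl group brings a double bond outside aromatic rings that no measured compound carries, so the expectation rests only on the steadiness seen so far. The step of a 1.1-fold higher number from compound 3 to compound 4 (0.02 log units; within the scatter) is therefore expected to stay within the scatter. The estimate for compound 4 in this assay is 50000 nM, with a range from 25000 nM to 100000 nM.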

Compound 4, half-maximal cytotoxic concentration: 163000 nM
Compound 4: middle estimate off by 3.3-fold (0.51 log units), on the low side; measured number above the stated range.
By their numbers in this assay, from the lowest: compounds 3, 1 and 2 (each within the scatter of the next); then compound 4.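

In this assay the carbonyl carbon had looked indifferent to its group while that group was a substituted phenyl, but 2-phenylethenyl produced a 3.4-fold higher number from compound 3 to compound 4 (0.53 log units; beyond the scatter) and a 2.8-fold higher number from compound 2 to compound 4 (0.44 log units; beyond the scatter) and a 3.0-fold higher number from compound 1 to compound 4 (0.48 log units; beyond the scatter) at the same place, each pointing to lower toxicity in this test. Compounds 1, 2 and 3 stand within the scatter of one another, so compound 4 is separated from all three and the position is not as insensitive as they suggested. The leaving and entering groups match in their counted heavy atoms, and the counted difference is the double bond outside aromatic rings, though nothing shown offers an explanation for the step.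

It remains open whether the double bond or the chain itself goes with the higher number, as a saturated 2-phenylethyl group on this carbonyl carbon is not among the compounds shown. Also open, from the compounds shown here alone, is how a 2-phenylethenyl group carrying a chlorine on its ring would read here.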